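This account rests on a few compounds, and the source may have more. Where it says the series, first, only, none or still open, it means among the compounds named here.

Series notes. In a functional assay on MCF7 cells (Homo sapiens) for antiproliferative activity, read by MTT assay, with a stated time of 48 h (on this read-out lower numbers stand for stronger inhibition and higher numbers for weaker inhibition), compound 1 `COc1ccc(C2OC(c3ccc4ccccc4c3)=NN2C(C)=O)cc1` gives 7.35 ug/mL. Compound 2 `CC(=O)N1N=C(c2ccc3ccccc3c2)OC1c1cccc(F)c1` gives 1.98 ug/mL. For the measured compounds named here, the single step measured so far, a 3.7-fold lower number from compound 1 to compound 2 (0.57 log units; beyond the scatter), accompanies 3-fluorophenyl in place of 4-methoxyphenyl on a saturated ring carbon. Compound 2 therefore holds the lowest of the two numbers. Compound 3 `CC(=O)N1N=C(c2ccc3ccccc3c2)OC1c1ccccn1` differs from compound 2 by pyridin-2-yl in place of 3-fluorophenyl on a saturated ring carbon. Going by the values given here, only the step from compound 1 to compound 2 bears on this change, and it concerns a different aryl exchange, so it is a rough guide at best; a modest step toward a higher number in this assay is expected, a 1.8-fold higher number from compound 2 to compound 3 (0.25 log units; within the scatter). Compound 3 is estimated at 3.5 ug/mL, within a range of 1.2 ug/mL to 10 ug/mL.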

Compound 3, half-maximal inhibitory concentration: 6.02 ug/mL
Estimate against measurement, compound 3: 1.7-fold (0.24 log units) below; low and high end bracket the measured number.
By their numbers in this assay, from the lowest: compound 2; then compounds 3 and 1 (each within the scatter of the next).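

In this assay the advantage of 3-fluorophenyl on this saturated ring carbon does not carry over to pyridin-2-yl, with a 3.0-fold higher number from compound 2 to compound 3 (0.48 log units; beyond the scatter) as the step. Pyridin-2-yl and 4-methoxyphenyl are not separated, with a 1.2-fold lower number from compound 1 to compound 3 (0.09 log units; within the scatter) as the step, so only 3-fluorophenyl stands apart among these three groups. Nothing at hand explains this order. Still open, on these data alone, is whether a chlorophenyl or a cyclohexyl group on this carbon would match 3-fluorophenyl. The compounds shown also leave open whether the acetyl group can be exchanged for a longer acyl chain.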